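An aromatic ring returns to the amide-type nitrogen

The source may report more compounds than this note shows. Statements on the series, on what has been measured and on what is new or still open speak of the compounds shown alone.

Of the compounds shown here, two that share one core have been measured in a functional assay on T-24 cells (Homo sapiens) for antiproliferative activity, read by MTT assay, with a stated time of 48 h; a lower number here means a stronger inhibitor, a higher number a weaker inhibitor. Compound 1 (`O=C(Nc1cccc(Cl)c1)Nc1cccc(CNc2nccnc2Cl)c1`), which carries 3-chlorophenyl, gives 6810 nM. Compound 2 (`O=C(Nc1cccc(CNc2nccnc2Cl)c1)NC1CCCC1`), which carries cyclopentyl, gives > 40000 nM, and this is a limit and not a number. Compound 2 thus stands at the limit of > 40000 nM in this assay, at which 1 of the 2 values shown sits.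

Compound 3 (`Cc1ccccc1NC(=O)Nc1cccc(CNc2nccnc2Cl)c1`) alters compound 2 on the amide-type nitrogen: 2-methylphenyl in place of cyclopentyl on an amide-type nitrogen. In words, 2-methylphenyl takes the place of cyclopentyl. Among the measured compounds shown here, only one measured step bears on this change, and it concerns the same place: cyclopentyl in place of 3-chlorophenyl gave an at least 5.8-fold higher number from compound 1 to compound 2 (0.76 log units; beyond the scatter). Compound 3 restores a six-membered aromatic ring there, so most of that loss is expected to be recovered. For the measured compounds named here, the recovery may be incomplete, since 2-methylphenyl is not 3-chlorophenyl and no measured pair compares the two groups. The expected change is an at least 3.3-fold lower number from compound 2 to compound 3 (0.52 log units; beyond the scatter) in this assay, an estimate that points towards a lower number. For compound 3 the estimated value is 12000 nM, with an expected range from 4500 nM to 32000 nM.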

Compound 3, half-maximal inhibitory concentration: 13600 nM
For compound 3 the middle estimate is 1.1-fold (0.05 log units) below the measured one, within the range that was stated.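

In this assay, the change on the amide-type nitrogen gives an at least 2.9-fold lower number from compound 2 to compound 3 (0.46 log units; beyond the scatter), so the drop seen with cyclopentyl is now set against a second aromatic group and not against 3-chlorophenyl alone. On these data alone, the value of compound 2 is a limit and not a number, which means this step is a bound and its true size stays unknown: the limit of > 40000 nM in this assay, at which 1 of the 3 values shown sits. The two aromatic groups are not separated at this position, with a 2.0-fold higher number from compound 1 to compound 3 (0.30 log units; within the scatter), so the compounds shown give no ground for preferring 3-chlorophenyl or 2-methylphenyl, even though the two groups differ in what they carry and in where they carry it.

The step from cyclopentyl to 2-methylphenyl changes ring size and aromatic character at once, and cyclohexyl on the same nitrogen would separate the two. Unsubstituted phenyl would show how much of the difference from compound 2 belongs to the aromatic ring itself and how much to the methyl or chloro group on it, and that question remains open here.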